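A Benzyl-to-Methoxyphenoxy Step in Cell Toxicity

A few compounds are considered here, and "the series" means these few. Any claim that something is new, unique, unknown or untested is made for them only; others in the source may bear on it.

Compound 1, `c1ccc(CCc2ccc3c(NCCCNCc4ccco4)ccnc3c2)cc1`, gives 16000 nM in an ADME assay on HepG2 cells (Homo sapiens) for cytotoxicity, read by luminescence, CellTiter-Glo and ATP content, with a stated time of 72 h; a higher number here means that more compound is needed for the effect, a lower number that less compound is needed.
Compound 2, `CC(C)CCc1ccc2c(NCCCNCc3ccco3)ccnc2c1`, gives 11200 nM in this assay.
Compound 3, `c1ccc(Cc2ccc3c(NCCCNCc4ccco4)ccnc3c2)cc1`, gives 16000 nM in this assay.

Compound 3 stands level with compound 1 at the digits printed, the two together the highest of the three numbers; its nearest neighbour is compound 1 and its furthest is compound 2, and the step of a 1.4-fold higher number from compound 2 to compound 3 (0.15 log units; within the scatter) lies within the scatter, as do a 1.4-fold lower number from compound 1 to compound 2 (0.15 log units; within the scatter) and no change at the digits printed from compound 1 to compound 3 (within the scatter). Compound 4, `COc1ccccc1Oc1ccc2c(NCCCNCc3ccco3)ccnc2c1`, differs from compound 3 by 2-methoxyphenoxy in place of benzyl on an aromatic carbon. The measured steps that bear on this change are those at the same place on the shared core, no change at the digits printed from compound 1 to compound 3 (within the scatter) and a 1.4-fold higher number from compound 2 to compound 3 (0.15 log units; within the scatter), and neither moved the number beyond the scatter. Going by the values given here, none of the measured compounds carries a group with hydrogen-bond acceptors at this place, so the data give no direct guide to that part of the change; what they show is that three different groups here left the number essentially unchanged. Compound 4 is therefore expected to give 16000 nM in this assay, with a range from 6000 nM to 40000 nM. The step of no change at the digits printed from compound 3 to compound 4 (within the scatter) is expected to be none beyond the scatter.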

Compound 4, half-maximal effective concentration: 6500 nM
For compound 4 the middle estimate is 2.5-fold (0.39 log units) above the measured one, and the stated range covers the measured number.
By their numbers in this assay, from the lowest: compounds 4, 2, 1 and 3 (each within the scatter of the next, the first and the last beyond it).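

Going by these compounds alone, compound 4 gives the first step beyond the scatter at this place in this assay, though a modest one: a 2.5-fold lower number from compound 3 to compound 4 (0.39 log units; beyond the scatter), and likewise a 2.5-fold lower number from compound 1 to compound 4 (0.39 log units; beyond the scatter). The position is therefore not wholly indifferent to what it carries, although the separation is only partial, as a 1.7-fold lower number from compound 2 to compound 4 (0.24 log units; within the scatter) remains within the scatter. Among these four compounds, 2-methoxyphenoxy is the only group at this place with hydrogen-bond acceptors, but no measurement bears on why the number shifts with this change.

The compounds shown leave open whether the step goes with the oxygen that joins the ring to the core or with the methoxy group. They also leave open whether a plain phenoxy group or an amine at this place would give a number like that of compound 4.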